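The source may report more compounds than this note shows. Statements on the series, on what has been measured and on what is new or still open speak of the compounds shown alone.

Compound 1, `Cc1cc(NC(=O)Cn2nnc(-c3ccccc3)n2)n(Cc2ccccc2)n1`: 74%
Compound 2, `Cc1cc(NC(=O)Cn2nnc(-c3ccccn3)n2)n(C2CCCCC2)n1`: 81%

In an assay on HEK293 cells for activation of Kir3.1/Kir3.2 (Homo sapiens), read by thallium flux (on this read-out higher numbers stand for larger maximal responses and lower numbers for smaller maximal responses), compound 2 gives 81%. Its nearest neighbour is compound 1, which gives 74% in this assay; the two numbers lie within the usual scatter of each other, so the data do not set compound 2 apart from compound 1. The two compounds also differ in more than one place, so no single step can be read from them.

Compound 3, `Cc1cc(NC(=O)Cn2nnc(-c3cccc(F)n3)n2)n(C2CCCCC2)n1`, has not yet been measured in this assay. It differs from compound 2 in one place, (fluoro in place of hydrogen on an aromatic carbon). Among the compounds with values here, no step between measured compounds bears on this change, and nothing in the two values shown points in either direction. Compound 3 is therefore expected to sit close to compound 2, with a step from compound 2 to compound 3 of a number 3 percentage points lower from compound 2 to compound 3 (within the scatter) that stays within the scatter. The estimate for compound 3 in this assay is 78%, with a range from 60% to 95%.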

Compound 3, largest response reached (Emax), in percent of the reference or control that the assay uses: > 83%
Compound 3: a limit, no number; the forecaster's own chance of this, stated with the estimate: 0%; at least 5 percentage points between middle value and limit.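

The change from pyridin-2-yl to 6-fluoropyridin-2-yl gives a number at least 2 percentage points higher from compound 2 to compound 3 (that floor lies within the scatter). In this assay, within the data shown here, compound 3 gives > 83%, which is a limit of the assay and not a number, so a fluoro group on this aromatic carbon, next to the ring nitrogen, brings no visible loss of maximal response, something the earlier compounds could not show. The one result that bears on how far the response goes is that limit itself: the limit of > 83% in this assay, at which 1 of the 3 values shown sits.

As far as these compounds go, the true size of the step stays open, since only its floor is known and that floor does not show whether the step goes beyond the scatter. Also open, from the compounds shown here alone, is whether a chloro group, a methoxy group or a nitrile on the same carbon would keep the response as the fluoro group does.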